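A few compounds are considered here, and "the series" means these few. Any claim that something is new, unique, unknown or untested is made for them only; others in the source may bear on it.

Measured in an assay on isolated protein for inhibition of DNA topoisomerase 1 (Homo sapiens), with a stated time of 30 min, tested at 20 uM; on this read-out higher numbers stand for a stronger effect at the one concentration tested and lower numbers for a weaker effect:
compound 1 `Oc1cccc(-c2cc(-c3cccs3)cc(-c3cccc(O)c3)n2)c1` — 0%
compound 2 `Oc1cccc(-c2cc(-c3ccco3)cc(-c3cccc(O)c3)n2)c1` — 0%
compound 3 `Oc1ccc(-c2cc(-c3ccco3)cc(-c3cccc(O)c3)n2)cc1` — 1.5%

Compound 2 sits level with compound 1 at the digits recorded, the two together the lowest of the three numbers; compound 3 lies a number 1.5 percentage points higher from compound 2 to compound 3 (within the scatter), a difference within the scatter. Compound 4 `Oc1cccc(-c2cc(-c3ccoc3)cc(-c3cccc(O)c3)n2)c1` is not yet measured; it differs from compound 2 by furan-3-yl in place of furan-2-yl on an aromatic carbon.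

Among the compounds with values here, two measured steps bear on this change. The swap of the five-membered ring gave no change at the digits printed from compound 1 to compound 2 (within the scatter), and the shift of the hydroxyl gave a number 1.5 percentage points higher from compound 2 to compound 3 (within the scatter); neither left the scatter, and all three numbers sit at the floor of this assay. Another rearrangement of the five-membered ring is therefore expected to give a number 1 percentage points higher from compound 2 to compound 4 (within the scatter), nothing beyond the scatter. Compound 4 is estimated at 1%, in the range -5% to 8%.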

Compound 4, a percentage reported as inhibition, at one concentration (the size of the read-out at that concentration, not a potency): 2%
Compound 4: the middle estimate sits 1 percentage points below what was measured; low and high end bracket the measured number.
By their numbers in this assay, from the lowest: compounds 1, 2, 3 and 4 (each within the scatter of the next).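

In this assay the change to furan-3-yl gives a number 2 percentage points higher from compound 2 to compound 4 (within the scatter) and the replacement of thiophen-2-yl by furan-3-yl gives a number 2 percentage points higher from compound 1 to compound 4 (within the scatter). At this position, opposite the ring nitrogen, neither the point of attachment of the furan nor the exchange of thiophen-2-yl for furan-3-yl leaves the scatter, so all three five-membered aromatic rings read alike. No evidence on the origin of this flat read-out is available. Still open, from the compounds shown here alone, is whether an amine, a carboxylic acid or a longer chain at this position would lift the number clear of the scatter.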